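Extending the Nitrofuran Amide Toward a Phenoxymethyl Arm

The compounds below may be only part of what the source reports. "The series", "measured", "known", "first", "only" and "open" are said of these compounds alone.

Measured compounds:
compound 1 `CC(C)(NC(=O)c1ccc([N+](=O)[O-])o1)c1ccccc1` — > 180000 nM
compound 2 `O=C(NCc1ccc(COc2ccc(Cl)cc2)cc1)c1ccc([N+](=O)[O-])o1` — 4000 nM

In an ADME assay on Vero cells (Chlorocebus sabaeus) for cytotoxicity, read by MTT assay, with a stated time of 48 h (on this read-out lower numbers stand for higher toxicity in this test and higher numbers for lower toxicity in this test), compound 1 gives > 180000 nM, which is a limit of the test rather than a number, as shown by the limit of > 180000 nM in this assay, at which 1 of the 2 values shown sits. In this assay compound 2 gives 4000 nM. Compound 3 `COc1ccc(OCc2ccc(C(C)(C)NC(=O)c3ccc([N+](=O)[O-])o3)cc2)cc1` differs from compound 1 by (4-methoxyphenoxy)methyl in place of hydrogen on an aromatic carbon. The step from compound 1 to compound 3 is expected to be large, toward higher toxicity, at an at least 15-fold lower number from compound 1 to compound 3 (1.17 log units; beyond the scatter). Compound 3 is expected to give 12000 nM, within a range from 3000 nM to 70000 nM.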

Compound 3, half-maximal cytotoxic concentration in the Vero assay: > 120000 nM
Compound 3: only a limit was reported; the forecaster's own chance of this, stated with the estimate: 15%; middle value at least 10-fold (1.00 log units) away from the limit.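

In the Vero assay compound 1 gives > 180000 nM, which is a limit of the test. In the Vero assay compound 3 gives > 120000 nM, which is also a limit of the test. The step between them cannot be read. The compounds shown leave open whether (4-methoxyphenoxy)methyl in place of hydrogen changes the half-maximal cytotoxic concentration at all. In a physicochemical assay for solubility, in phosphate buffer, measured as kinetic solubility, at pH 7.4 (on this read-out higher numbers stand for higher solubility and lower numbers for lower solubility), compound 1 gives 388000 nM. In the physicochemical assay compound 3 gives < 60 nM, which is a limit of the test.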